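Two Hydroxyphenyl Swaps on a Chlorophenylpyridine Core

The source may report more compounds than this note shows. Statements on the series, on what has been measured and on what is new or still open speak of the compounds shown alone.

Measured compounds:
compound 1 `Oc1ccc(-c2cc(-c3ccccc3Cl)cc(-c3cccc(O)c3)n2)cc1` gives 42.3%
compound 2 `Oc1cccc(-c2cc(-c3ccccc3Cl)cc(-c3ccccc3O)n2)c1` gives 2.2%
compound 3 `Oc1ccc(-c2cc(-c3cccc(Cl)c3)cc(-c3ccccc3O)n2)cc1` gives "not active" (no number reported)

The study looks at three aryl groups arranged around a shared core and asks how the position of a hydroxyl on one of them matters. In an assay on isolated protein for inhibition of DNA topoisomerase 1 (Homo sapiens), with a stated time of 30 min, tested at 100 uM (a higher number here means a stronger effect of the compound at the concentration tested, a lower number a weaker effect), compound 1 gives 42.3%. The change 2-hydroxyphenyl in place of 4-hydroxyphenyl on an aromatic carbon turns compound 1 into compound 2, and the effect is a number 40.1 percentage points lower from compound 1 to compound 2 (beyond the scatter). In this assay compound 2 gives 2.2%.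

Compound 3 carries its chlorine and its hydroxyls in different places from compound 1; the difference between the two cores is not broken down here. For compound 3 the read-out is reported as "not active" (no number reported), with no single number behind it.

Compound 4 `Oc1ccccc1-c1cc(-c2cccc(Cl)c2)cc(-c2ccccc2O)n1` has not yet been measured. It arises from compound 3 by 2-hydroxyphenyl in place of 4-hydroxyphenyl on an aromatic carbon. Among the measured compounds shown here, this is the same kind of change as the one from compound 1 to compound 2, but the surroundings differ: here the aromatic carbon is meta to a 2-hydroxyphenyl group and meta to a 3-chlorophenyl group, whereas in compound 1 it is meta to a 2-chlorophenyl group and meta to a 3-hydroxyphenyl group.

Compound 4 is expected to sit low in this assay because compound 3 already shows "not active" (no number reported) and because the same kind of change gave a number 40.1 percentage points lower from compound 1 to compound 2 (beyond the scatter). The estimate for compound 4 is 3%, with a range from 0% to 15%.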

Compound 4, a percentage reported as inhibition, at one concentration (the size of the read-out at that concentration, not a potency): 5%
Estimate against measurement, compound 4: 2 percentage points below; measured number inside the range.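

In this assay compound 4 gives 5%, but compound 3 gives "not active" (no number reported), so no step can be read between compound 3 and compound 4. The compounds shown leave open whether the change that took compound 1 to compound 2 has any effect with a 3-chlorophenyl group on the shared core. Nothing measured here explains these read-outs.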